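Swapping the Furan Substituent of an Allosteric Modulator

The compounds below may be only part of what the source reports. "The series", "measured", "known", "first", "only" and "open" are said of these compounds alone.

Compounds measured so far:
compound 1, `Cc1cc(N2C(=O)C3=C(CCCC3)C2=O)c(F)cc1NC(=O)c1occc1C`: 58 nM
compound 2, `Cc1ccoc1C(=O)Nc1c(F)cc(N2C(=O)CC3(CCCC3)CC2=O)c(F)c1F`: 1980 nM

In a functional assay for positive allosteric modulation of metabotropic glutamate receptor 1 (Homo sapiens), read by calcium flux, in the presence of a further agent that is not named here (on this read-out lower numbers stand for an effect already at smaller amounts and higher numbers for an effect only at larger amounts of compound), compound 1 has the lowest of the two numbers; compound 2 lies beyond the scatter with its higher value, but the two differ in several places, so the pair tells nothing about any single change. Compound 3, `Cc1cc(N2C(=O)C3=C(CCCC3)C2=O)c(F)cc1NC(=O)c1ccc(Cl)o1`, differs from compound 1 in one place: 5-chlorofuran-2-yl in place of 3-methylfuran-2-yl on a carbonyl carbon. Among the compounds with values here, no measured pair shows this change, so the step from compound 1 to compound 3 is expected to be small, probably within the scatter or a slight move toward higher numbers, estimated as a 1.7-fold higher number from compound 1 to compound 3 (0.24 log units; within the scatter). Compound 3 is therefore expected near 100 nM, between 30 nM and 400 nM.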

Compound 3, half-maximal effective concentration: > 10000 nM
Compound 3: a limit, no number; the forecaster's own chance of this, stated with the estimate: 5%; middle value at least 100-fold (2.00 log units) from the limit.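

In this assay, the furan substituent on the carbonyl carbon proves to be a sensitive place, which compound 1 and compound 2 could not show because they differ in several places. With the heavy-atom count unchanged, 5-chlorofuran-2-yl in place of 3-methylfuran-2-yl gives an at least 170-fold higher number from compound 1 to compound 3 (2.23 log units; beyond the scatter). For compound 3 the result is a limit, not a number: the limit of > 10000 nM in this assay, at which 1 of the 3 values shown sits.

The step moves the furan substituent and changes it from methyl to chlorine at once, so the compounds shown leave open which of the two matters. Furan-2-yl without a substituent, 5-methylfuran-2-yl or 3-chlorofuran-2-yl would separate them.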